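Compound 3 to compound 4: lengthening the chain

The source may report more compounds than this note shows. Statements on the series, on what has been measured and on what is new or still open speak of the compounds shown alone.

In a functional assay on WM164 cells (Homo sapiens) for antiproliferative activity, read by sulforhodamine B assay, with a stated time of 48 h (on this read-out higher numbers stand for weaker inhibition and lower numbers for stronger inhibition), compound 3 (`CCCCCCCCCCCCNC(=O)[C@@H]1CSC(c2ccc(N)cc2)N1`) gives 1400 nM as its value. Compound 1 (`CCCCCCCCCCCCCCCCNC(=O)[C@@H]1CSC(c2cc(OC)c(OC)c(OC)c2)N1`) gives 700 nM and lies within the scatter of compound 3. Compound 2 (`CCCCCCCCCCCCCCCCNC(=O)[C@@H]1CSC(c2ccc(NC(C)=O)cc2)N1`) gives 600 nM and lies below compound 3 beyond the scatter. The change to compound 4 (`CCCCCCCCCCCCCCCCNC(=O)[C@@H]1CSC(c2ccc(N)cc2)N1`) is butyl in place of hydrogen on a saturated chain carbon, ten or more bonds along the chain from an amide-type nitrogen and gives it the chain of compound 1 and compound 2. For the measured compounds named here, no measured step changes the chain alone. Going by the values given here, the only measured step is a 1.2-fold lower number from compound 1 to compound 2 (0.07 log units; within the scatter) and it leaves the chain untouched. Compound 4 is therefore expected to sit near compound 1 and compound 2 despite the different group on its saturated ring carbon. The expected step is a 2.2-fold lower number from compound 3 to compound 4 (0.33 log units; beyond the scatter) toward a lower number, with real uncertainty. In this assay compound 4 is estimated at 650 nM within a range from 280 nM to 1400 nM on this reasoning.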

Compound 4, half-maximal inhibitory concentration: 1400 nM
Compound 4: middle estimate off by 2.2-fold (0.33 log units), on the low side; low and high end bracket the measured number.
By their numbers in this assay, from the lowest: compounds 2, 1, 3 and 4 (each within the scatter of the next, the first and the last beyond it).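

In this assay butyl in place of hydrogen gives no change at the digits printed from compound 3 to compound 4 (within the scatter) and so, with the 4-aminophenyl group held, this chain lengthening leaves the number flat. Hydrogen in place of acetyl on a nitrogen on an aromatic ring gives a 2.3-fold higher number from compound 2 to compound 4 (0.37 log units; beyond the scatter) and is the only one of these steps beyond the scatter, while 4-aminophenyl in place of 3,4,5-trimethoxyphenyl gives a 2.0-fold higher number from compound 1 to compound 4 (0.30 log units; within the scatter) and stays within it. Nothing available accounts for these steps. From the compounds shown here alone, whether a longer chain than that of compound 4 or a shorter one than that of compound 3 would shift the number stays open, as does whether the flat chain step holds with the 4-acetamidophenyl group.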